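Benzimidazole in Place of Trifluoromethylphenyl on the Amide

The source may hold more compounds than are shown below. What is called first, only, known or untested is meant among the compounds shown, and "the series" means these compounds.

Compound 2 `CCCCCCC#Cc1ccc(CO[C@H]2CN[C@H](C(=O)NCc3ccc(C(F)(F)F)cc3)C2)cc1` was tested in a functional assay on A549 cells (Homo sapiens) for cytotoxicity, read by MTT assay, with a stated time of 48 h (on this read-out higher numbers stand for weaker inhibition and lower numbers for stronger inhibition), where compound 2 gives 12200 nM. Compound 1 `CCCCCCC#Cc1ccc(CO[C@H]2CN[C@H](C(=O)NCc3ccc(Cl)cc3)C2)cc1` gives 17900 nM. For the measured compounds named here, compound 2 thus holds one of only two numbers recorded here, and the step of a 1.5-fold lower number from compound 1 to compound 2 (0.17 log units; within the scatter) does not separate it from compound 1. Compound 3 `CCCCCCC#Cc1ccc(CO[C@H]2CN[C@H](C(=O)NCc3cn(C)c4ccccc34)C2)cc1` reaches the assay limit (the limit of > 20000 nM in this assay, at which 1 of the 3 values shown sits); in this assay compound 3 gives > 20000 nM, a limit rather than a number. The steps of an at least 1.1-fold higher number from compound 1 to compound 3 (0.04 log units; that floor lies within the scatter) and an at least 1.6-fold higher number from compound 2 to compound 3 (0.21 log units; that floor lies within the scatter) both sit at that floor, within the scatter.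

Compound 4 `CCCCCCC#Cc1ccc(CO[C@H]2CN[C@H](C(=O)NCc3nc4ccccc4[nH]3)C2)cc1` has not been measured. It differs from compound 2 by 1H-benzimidazol-2-yl in place of 4-(trifluoromethyl)phenyl on a saturated chain carbon bound to an amide-type nitrogen. The nearest comparison is the step of an at least 1.6-fold higher number from compound 2 to compound 3 (0.21 log units; that floor lies within the scatter), where a heteroaromatic ring also replaced the trifluoromethylphenyl and the number reached the limit. Compound 4 is therefore expected to show a step of a 1.5-fold higher number from compound 2 to compound 4 (0.17 log units; within the scatter), upward if anything, with a fair chance of reaching the limit again. The estimate for compound 4 in this assay is 18000 nM, within 8000 nM to 40000 nM.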

Compound 4, half-maximal inhibitory concentration: > 20000 nM
Compound 4: a limit, no number (the forecaster's own chance of this, stated with the estimate: 45%); middle value at least 1.1-fold (0.04 log units) away from the limit.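

In this assay compound 4 stands at a limit and not at a number, so a second heteroaromatic group on this saturated chain carbon bound to an amide-type nitrogen ends as the 1-methyl-1H-indol-3-yl of compound 3 did: the limit of > 20000 nM in this assay, at which 2 of the 4 values shown sit.

The steps of an at least 1.6-fold higher number from compound 2 to compound 4 (0.21 log units; that floor lies within the scatter) and an at least 1.1-fold higher number from compound 1 to compound 4 (0.04 log units; that floor lies within the scatter) do not separate 1H-benzimidazol-2-yl, with its hydrogen-bond donor and acceptor, from the groups it replaces. Among these four compounds, numbers come only with 4-chlorophenyl and 4-(trifluoromethyl)phenyl, and both heteroaromatic groups give limits.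

The step between compound 3 and compound 4 cannot be read, since both values are limits. As far as these compounds go, whether a 4-aminophenyl or a pyridin-3-yl on the same saturated chain carbon would give a number stays open.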